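Hydroxamic acid cyclopropane in place of the thioacetic acid

This account rests on a few compounds, and the source may have more. Where it says the series, first, only, none or still open, it means among the compounds named here.

Series notes. In a functional assay on CHO cells for agonist activity at Free fatty acid receptor 1 (Homo sapiens) (on this read-out higher numbers stand for an effect only at larger amounts of compound and lower numbers for an effect already at smaller amounts), compound 1 `O=C(O)CSc1ccc(NCc2cccc(Oc3ccccc3)c2)cc1` gives 324 nM, the lowest of the two numbers shown; compound 2 `Cc1nc(-c2ccc(C(F)(F)F)cc2)sc1CNc1ccc(CC(C)C(=O)O)cc1` gives 355 nM in this assay, within the scatter of compound 1. Compound 3 `O=C(NO)[C@H]1C[C@@H]1c1ccc(NCc2cccc(Oc3ccccc3)c2)cc1` is not yet measured in this assay. It differs from compound 1 as follows: 2-(hydroxycarbamoyl)cyclopropyl in place of (carboxymethyl)sulfanyl on an aromatic carbon. For the measured compounds named here, no measured pair shows this change, so the expected step of a 2.0-fold higher number from compound 1 to compound 3 (0.30 log units; within the scatter) is only a guess, leaning towards a larger number. On that basis compound 3 is estimated at 650 nM in this assay, with a range from 150 nM to 3000 nM.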

Compound 3, half-maximal effective concentration: 14.8 nM
Compound 3: middle estimate off by 44-fold (1.64 log units), on the high side, and the stated range ends above it.
By their numbers in this assay, from the lowest: compound 3; then compounds 1 and 2 (each within the scatter of the next).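

At the aromatic carbon para to a large group in the core of compound 1, in this assay, replacing (carboxymethyl)sulfanyl with 2-(hydroxycarbamoyl)cyclopropyl gives a 22-fold lower number from compound 1 to compound 3 (1.34 log units; beyond the scatter). This position therefore accepts a group without a carboxylic acid, and the change is large. No measurement available here bears on the cause of this step.

The step changes the linker and the end group together, so their shares remain unresolved; a carboxylic acid on the same cyclopropane would separate them. As far as these compounds go, the opposite stereoisomer of the cyclopropane also remains open.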